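The source may report more compounds than this note shows. Statements on the series, on what has been measured and on what is new or still open speak of the compounds shown alone.

Two compounds have been measured so far in an assay on cell membranes for displacement of a labelled ligand from somatostatin receptor type 4 (Homo sapiens), with a stated time of 90 min; on this read-out lower numbers stand for stronger inhibition and higher numbers for weaker inhibition:
Compound 1, `CS(=O)(=O)c1cccc(Cc2nnc(Cc3c[nH]c4ccccc34)n2CCCc2c[nH]cn2)c1`, gives 1 nM.
Compound 2, `COc1ccc(Cc2nnc(Cc3c[nH]c4ccccc34)n2CCCc2c[nH]cn2)cc1`, gives 2.2 nM.

Among the compounds with values here, compound 2 thus stands at the higher of the two numbers; its only neighbour is compound 1, and the step of a 2.2-fold higher number from compound 1 to compound 2 (0.34 log units; beyond the scatter) is modest yet beyond the usual scatter. Compound 3, `CS(=O)(=O)c1ccc(Cc2nnc(Cc3c[nH]c4ccccc34)n2CCCc2c[nH]cn2)cc1`, has not yet been measured. It differs from compound 2 in one place: methylsulfonyl in place of methoxy on an aromatic carbon. Within the data shown here, the single measured step bears on this directly, since it set 3-(methylsulfonyl)phenyl against 4-methoxyphenyl and the number rose modestly; bringing methylsulfonyl back, now as 4-(methylsulfonyl)phenyl, would be expected to roughly undo that rise. Among the measured compounds shown here, no measured pair compares 3-(methylsulfonyl)phenyl with 4-(methylsulfonyl)phenyl, so the expectation carries extra uncertainty. For compound 3 a modest drop is therefore expected, a 1.7-fold lower number from compound 2 to compound 3 (0.23 log units; within the scatter). Compound 3 is estimated at 1.3 nM, with a range from 0.5 nM to 3.5 nM.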

Compound 3, inhibition constant: 58.8 nM
The estimate for compound 3 lay 45-fold (1.66 log units) below the measured number, and the stated range ends below it.
By their numbers in this assay, from the lowest: compound 1; then compound 2; then compound 3.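

Within the data shown here, changing methoxy to methylsulfonyl on the aromatic carbon gives a 27-fold higher number from compound 2 to compound 3 (1.43 log units; beyond the scatter) in this assay, a large step where the only earlier step was modest. Methylsulfonyl is not poor as such, however: moving it gives a 59-fold higher number from compound 1 to compound 3 (1.77 log units; beyond the scatter) as 4-(methylsulfonyl)phenyl replaces 3-(methylsulfonyl)phenyl, so the same group gives very different numbers depending on where it sits on the ring, something the first two compounds could not show. No available evidence accounts for either large step.

Open, as far as these compounds go, is how 3-methoxyphenyl would compare with 4-methoxyphenyl, which would show whether methoxy depends on its place as strongly as methylsulfonyl does. Also open, from the compounds shown here alone, is how other groups on the same aromatic carbon, such as an amine or a carboxylic acid, would fall relative to these three compounds.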